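A few compounds are considered here, and "the series" means these few. Any claim that something is new, unique, unknown or untested is made for them only; others in the source may bear on it.

Among the compounds with values here, in an assay on CHO cells for displacement of a labelled ligand from prostaglandin D2 receptor 2 (Homo sapiens), read by scintillation counting (a lower number here means a stronger inhibitor, a higher number a weaker inhibitor), compound 2 `Cc1ccc(S(=O)(=O)N(C)CC(C)C)cc1C#Cc1cc(Cl)ccc1OCC(=O)O` stands lowest of the three numbers known so far, giving 4.2 nM. Compound 1 `CS(=O)(=O)Cc1cccc(C#Cc2cc(Cl)ccc2OCC(=O)O)c1` gives 48 nM, and compound 3 `CCCS(=O)(=O)c1cccc(C#Cc2c(OCC(=O)O)cccc2-c2sc(C)nc2C)c1` gives 54 nM; each of those two sits beyond the usual scatter above compound 2.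

Compound 4 `Cc1ccc(S(=O)(=O)N(C)C)cc1C#Cc1cc(Cl)ccc1OCC(=O)O` is compound 2 with one change: hydrogen in place of isopropyl on a saturated chain carbon bound to a sulfonamide nitrogen. Among the measured compounds no pair differs by this change alone, so there is no measured step to lean on. Trimming the chain on the sulfonamide nitrogen is expected to cost some potency, a step of a 2.9-fold higher number from compound 2 to compound 4 (0.46 log units; beyond the scatter) toward a higher number, small enough that it could still fall within the scatter. Compound 4 is therefore expected to give about 12 nM, with a likely range from 4 nM to 40 nM.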

Compound 4, inhibition constant: 5 nM
For compound 4 the middle estimate is 2.4-fold (0.38 log units) above the measured one; the range from low to high includes it.
By their numbers in this assay, from the lowest: compounds 2 and 4 (each within the scatter of the next); then compounds 1 and 3 (each within the scatter of the next).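

Putting hydrogen in place of isopropyl, which turns isobutyl(methyl)sulfamoyl into dimethylsulfamoyl, gives a 1.2-fold higher number from compound 2 to compound 4 (0.08 log units; within the scatter), so the two compounds read alike. This only one-place step in the set shows that the isopropyl end of this chain is not needed for a low number here. Nothing shown explains why the two compounds match. As far as these compounds go, what a chain ending in an amine or a carboxylic acid would do on this sulfonamide nitrogen remains open, as does the effect of a longer chain.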